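The source may report more compounds than this note shows. Statements on the series, on what has been measured and on what is new or still open speak of the compounds shown alone.

Within the data shown here, in a functional assay on KB cells (Homo sapiens) for inhibition (a lower number here means a stronger inhibitor, a higher number a weaker inhibitor), compound 1 `COc1ccc(Cn2c(N)c(C#N)c3c(N)ncnc32)cc1` gives 50000 nM, the only exact number so far. Compound 2 `N#Cc1c(Br)n(COCc2ccccc2)c2ncnc(N)c12` is reported only as a limit, > 100000 nM. Compound 3 `Cc1ccc(Cn2c(N)c(C#N)c3c(N)ncnc32)cc1` has not yet been measured. It carries methyl in place of methoxy on an aromatic carbon, para to a large group (methyl in place of methoxy on an aromatic carbon). Among the measured compounds shown here, no measured pair shows what this swap does, and the expectation in this assay is no step beyond the usual scatter. The expected step is no change at the digits printed from compound 1 to compound 3 (within the scatter). Compound 3 is estimated at 50000 nM, with an expected range from 20000 nM to 100000 nM.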

Compound 3, half-maximal inhibitory concentration: > 100000 nM
Compound 3 ended at the assay's limit (the forecaster's own chance of this, stated with the estimate: 25%); middle value at least 2.0-fold (0.30 log units) away from the limit.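

Methyl in place of methoxy, para to a large group, gives the first direct reading at this position in this assay, with an at least 2.0-fold higher number from compound 1 to compound 3 (0.30 log units; that floor lies within the scatter). The result for compound 3 is a limit and not a number, so the true size of this step cannot be read, and its floor does not separate the two compounds. Limits are common in this small set: the limit of > 100000 nM in this assay, at which 2 of the 3 values shown sit.

Going by these compounds, whether an amine, a hydroxyl or a longer chain such as ethoxy in place of the methoxy would give a lower number than compound 1 remains open.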